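Removing a Nitro Group from a Glycosylated Fused Bicyclic Aryl Ether

The source may hold more compounds than are shown below. What is called first, only, known or untested is meant among the compounds shown, and "the series" means these compounds.

Measured compounds:
- compound 1, `OC[C@H]1O[C@H](Oc2ccc(-n3ccc4ccccc43)cc2F)[C@@H](O)[C@@H](O)[C@@H]1O`: 2.4
- compound 2, `O=[N+]([O-])c1ccc2c(ccn2-c2ccc(O[C@H]3O[C@H](CO)[C@@H](O)[C@H](O)[C@@H]3O)c(F)c2)c1`: 1.9
- compound 3, `O=[N+]([O-])c1ccc2c(c1)CCN2c1ccc(O[C@H]2O[C@H](CO)[C@@H](O)[C@H](O)[C@@H]2O)c(Cl)c1`: 1.9

Three compounds were measured in a physicochemical assay for lipophilicity, using the shake flask method, in phosphate buffer, measured as octanol-water partition, with a stated time of 2 h, at pH 7.4, tested at 1 uM; a lower number here means a more polar compound, a higher number a more lipophilic compound. Compound 2 and compound 3 stand level at the digits printed, and together they give the lowest two numbers of the three; compound 1 sits higher than both.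

Compound 1 and compound 2 share one core and differ in a single place: hydrogen in place of nitro on an aromatic carbon. This change is accompanied by a step in this assay of a number 0.50 log units higher from compound 2 to compound 1 (beyond the scatter), a modest movement that nonetheless lies beyond the usual scatter of repeated measurements.

Compound 4, `OC[C@H]1O[C@H](Oc2ccc(N3CCc4ccccc43)cc2Cl)[C@@H](O)[C@@H](O)[C@@H]1O`, has not yet been measured in this assay. It is related to compound 3 in exactly the same way: hydrogen in place of nitro on an aromatic carbon. The difference between the core of compound 3 and the core of compound 2 is not broken down here, so the two pairs are compared only through the change they have in common.

Since the change from compound 3 to compound 4 is the same as that from compound 2 to compound 1, and the place of the change is described in identical words, the step from compound 3 to compound 4 is expected to be about a number 0.50 log units higher from compound 3 to compound 4 (beyond the scatter) in this assay, resting on the measured step of a number 0.50 log units higher from compound 2 to compound 1 (beyond the scatter). On that basis compound 4 is estimated at 2.4, with a likely range from 2.1 to 2.7.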

Compound 4, distribution coefficient: 2.8
Compound 4: middle estimate off by 0.40 log units, on the low side; the measured number lies above the stated range.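

In this assay the exchange of nitro for hydrogen on an aromatic carbon gave a number 0.90 log units higher from compound 3 to compound 4 (beyond the scatter) and on the other core gave a number 0.50 log units higher from compound 2 to compound 1 (beyond the scatter) so in these two pairs the direction carried from one core to the other and both steps lie beyond the scatter, while the size of the step did not stay the same. Going by these compounds alone, this shows that the step measured on one core was a sound guide to the sign of the change on the other but not to its exact size, and with only two pairs it sets no rule for any further core. Nothing in the data explains why the step came out differently on the two cores, and the cores themselves differ in more than one place, so no separate contribution from either can be read.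

The compounds shown carry only nitro or hydrogen at this aromatic carbon, so it remains open how an amine, a carboxylic acid or a nitrile at the same place would stand in this assay on either core. Also open, on these data alone, is whether the same exchange on a third core would give a step closer to the one or the other of these two.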